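A few compounds are considered here, and "the series" means these few. Any claim that something is new, unique, unknown or untested is made for them only; others in the source may bear on it.

Compound 1 `Cc1nc2ccccc2c(=O)n1NS(=O)(=O)c1ccccc1`: 5.6%
Compound 2 `Cc1ccc(S(=O)(=O)Nn2c(C)nc3ccccc3c2=O)cc1`: 3.2%
Compound 3 `Cc1ccc(S(=O)(=O)Nn2c(CO[N+](=O)[O-])nc3ccccc3c2=O)cc1`: 6.4%

In a functional assay on the whole organism (strain Sprague-Dawley) for inhibition, with Rattus norvegicus as the target, read by paw edema, with stated times of 30 min and 1 h, at a dose of 80 mg/kg by the oral route (on this read-out lower numbers stand for less inhibition and higher numbers for more inhibition at the one dose given (going by the name of the read-out)), compound 2 holds the lowest of the three numbers, yet its gaps to compound 1 and to compound 3 both lie within the scatter, so no order among the three can be read. Compound 4 `CC(=O)Nc1ccc(S(=O)(=O)Nn2c(C)nc3ccccc3c2=O)cc1` differs from compound 2 by acetamido in place of methyl on an aromatic carbon. The step that bears most on this is the one at the same aromatic carbon, a number 2.4 percentage points lower from compound 1 to compound 2 (within the scatter), which stayed within the scatter; the step of a number 3.2 percentage points higher from compound 2 to compound 3 (within the scatter), at another site, also stayed within the scatter. Neither step gives a reason to expect compound 4 to move beyond the scatter in this assay. Compound 4 is therefore estimated at 4.5%, between 0% and 13%, an expected step of a number 1.3 percentage points higher from compound 2 to compound 4 (within the scatter).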

Compound 4, a percentage reported as inhibition, in the whole organism at one dose (the size of the read-out at that dose, not a potency): 20.8%
The estimate for compound 4 lay 16.3 percentage points below the measured number; the whole stated range lies below it.
By their numbers in this assay, from the lowest: compounds 2, 1 and 3 (each within the scatter of the next); then compound 4.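

For the compounds shown here, on the aromatic carbon para to a large group, acetamido gives the first steps beyond the scatter in this assay, namely a number 17.6 percentage points higher from compound 2 to compound 4 (beyond the scatter) and a number 15.2 percentage points higher from compound 1 to compound 4 (beyond the scatter). Methyl at this same carbon had left the number within the scatter, so this position does respond to at least one change. Nothing available here accounts for the rise.

The compounds shown leave open how an amine, a carboxylic acid or a longer acyl chain at this carbon would read. They also leave open whether acetamido would combine with the nitrooxy group of compound 3.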